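The source may hold more compounds than are shown below. What is called first, only, known or untested is meant among the compounds shown, and "the series" means these compounds.

Measured compounds: compound 1 `O=C(NC1CC1)c1cc(Oc2ccc(/C=C/c3ccccn3)cc2)ccn1` gives 31000 nM; compound 2 `O=C(NC1CCCCC1)c1cc(Oc2ccc(/C=C/c3ccccn3)cc2)ccn1` gives 20600 nM; compound 3 `O=C(NC1CC1)c1cc(Oc2ccc(/C=C/c3ccncc3)cc2)ccn1` gives 77500 nM, all in a functional assay on HepG2 cells (Homo sapiens) for antiproliferative activity, read by CCK-8 assay, with a stated time of 48 h; a lower number here means a stronger inhibitor, a higher number a weaker inhibitor.

Compound 1 and compound 2 differ by cyclohexyl in place of cyclopropyl on an amide-type nitrogen, and this change made a step of a 1.5-fold lower number from compound 1 to compound 2 (0.18 log units; within the scatter). Compound 3 carries a different core from compound 1, the difference being (pyridin-4-yl in place of pyridin-2-yl on a double-bonded chain carbon bound to a double-bonded chain carbon), which made a step of a 2.5-fold higher number from compound 1 to compound 3 (0.40 log units; beyond the scatter). Compound 4 `O=C(NC1CCCCC1)c1cc(Oc2ccc(/C=C/c3ccncc3)cc2)ccn1` is not yet measured; it differs from compound 3 by cyclohexyl in place of cyclopropyl on an amide-type nitrogen, the same change as from compound 1 to compound 2, made at the same kind of place. Because the earlier step of a 1.5-fold lower number from compound 1 to compound 2 (0.18 log units; within the scatter) was small, compound 4 is expected to show a step of about a 1.4-fold lower number from compound 3 to compound 4 (0.15 log units; within the scatter) in this assay. Compound 4 is therefore estimated at 55000 nM, between 25000 nM and 120000 nM.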

Compound 4, half-maximal inhibitory concentration: 22400 nM
The estimate for compound 4 lay 2.5-fold (0.39 log units) above the measured number; the measured number lies below the stated range.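

In this assay, cyclohexyl in place of cyclopropyl on an amide-type nitrogen gave a 3.5-fold lower number from compound 3 to compound 4 (0.54 log units; beyond the scatter), and this step cannot be told apart from the one seen earlier on the core of compound 1: the same change on two cores in this assay, a 1.5-fold lower number (0.18 log units; within the scatter) from compound 1 to compound 2 and a 3.5-fold lower number (0.54 log units; beyond the scatter) from compound 3 to compound 4, 2.3-fold (0.36 log units) apart, within the scatter of two such steps

Pyridin-4-yl in place of pyridin-2-yl gave a 1.1-fold higher number from compound 2 to compound 4 (0.04 log units; within the scatter), and this step likewise cannot be told apart from its earlier counterpart: the same change on two cores in this assay, a 2.5-fold higher number (0.40 log units; beyond the scatter) from compound 1 to compound 3 and a 1.1-fold higher number (0.04 log units; within the scatter) from compound 2 to compound 4, 2.3-fold (0.36 log units) apart, within the scatter of two such steps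

Each change therefore carries between these two cores within the scatter, but this does not show that the paired steps are equal, and one pair of cores says nothing about any other core.

The compounds shown leave open how a cyclopentyl or tert-butyl group on the amide-type nitrogen would compare. They also leave open how a pyridin-3-yl or phenyl group would compare on the double-bonded chain carbon.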